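Trifluoromethyl for Methoxy: An Expected Loss of Potency

A few compounds are considered here, and "the series" means these few. Any claim that something is new, unique, unknown or untested is made for them only; others in the source may bear on it.

Among the compounds with values here, in a functional assay on HT-29 cells (Homo sapiens) for cytotoxicity, read by MTT assay, with a stated time of 48 h (on this read-out lower numbers stand for stronger inhibition and higher numbers for weaker inhibition), compound 1 (`COC(=O)/C=C/c1ccc2c(c1)C(=O)C(=O)N2Cc1ccc(OC)cc1`) gives 30 nM, the lowest number of the three compounds measured so far. Compound 2 (`COC(=O)/C=C/c1ccc2c(c1)C(=O)C(=O)N2C`) gives 300 nM, and compound 3 (`COC(=O)/C=C/c1ccc2c(c1)C(=O)C(=O)N2Cc1ccc(Cl)c(Cl)c1`) gives 210 nM. Compound 4 (`COC(=O)/C=C/c1ccc2c(c1)C(=O)C(=O)N2Cc1ccc(C(F)(F)F)cc1`) has not yet been measured. It differs from compound 1 at one place: trifluoromethyl in place of methoxy on an aromatic carbon. In words, this is trifluoromethyl in place of methoxy on an aromatic carbon.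

Within the data shown here, no measured pair makes this exact change, so the nearest evidence comes from two other changes at the same substituent. Putting 3,4-dichlorophenyl in place of 4-methoxyphenyl gave a 7.0-fold higher number from compound 1 to compound 3 (0.85 log units; beyond the scatter), and putting hydrogen there gave a 10-fold higher number from compound 1 to compound 2 (1.00 log units; beyond the scatter). Both steps lie beyond the scatter and point the same way, while the remaining comparison is a 1.4-fold lower number from compound 2 to compound 3 (0.15 log units; within the scatter). Among the measured compounds shown here, only two changes support this trend, and neither goes against it. Compound 4 also loses the methoxy group, so a step to a higher number is expected in this assay, of about the size seen for compound 3 with its a 7.0-fold higher number from compound 1 to compound 3 (0.85 log units; beyond the scatter). The estimated step is a 5.7-fold higher number from compound 1 to compound 4 (0.75 log units; beyond the scatter). For compound 4 the estimated value is 170 nM, with an expected range from 60 nM to 450 nM.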

Compound 4, half-maximal inhibitory concentration: 40 nM
Estimate against measurement, compound 4: 4.3-fold (0.63 log units) above, outside the stated range (below it).
By their numbers in this assay, from the lowest: compounds 1 and 4 (each within the scatter of the next); then compounds 3 and 2 (each within the scatter of the next).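

In this assay, trifluoromethyl in place of methoxy gave a 1.3-fold higher number from compound 1 to compound 4 (0.12 log units; within the scatter), so at this position, on an aromatic carbon para to a large group, the methoxy group can be exchanged without a change beyond the scatter. The earlier steps shown here, a 10-fold higher number from compound 1 to compound 2 (1.00 log units; beyond the scatter) and a 7.0-fold higher number from compound 1 to compound 3 (0.85 log units; beyond the scatter), could be read as pointing to the methoxy group itself, but compound 4 shows that the low number of compound 1 does not depend on methoxy, and that it survives the loss of the hydrogen-bond acceptor counted on that group. Nothing measured here says why compound 4 stays with compound 1 while compound 3 does not.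

The compounds shown leave open whether any group is needed at this carbon at all, since a plain phenyl with only hydrogen there does not appear among them, and neither does a smaller substituent such as a single fluorine. They also leave open how far this tolerance reaches, for instance whether an amine, a carboxylic acid or a longer chain at the same carbon would keep the number near that of compound 1.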